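Hydrazone series: swapping the aryl ring on the imine carbon

The source may report more compounds than this note shows. Statements on the series, on what has been measured and on what is new or still open speak of the compounds shown alone.

Measured in a functional assay on HepG2 cells (Homo sapiens) for cytotoxicity, read by MTT assay, with a stated time of 48 h; on this read-out lower numbers stand for stronger inhibition and higher numbers for weaker inhibition:
- compound 1 `O=C(CSc1nnc(-c2ccncc2)o1)N/N=C/c1ccc(F)cc1` gives 12300 nM
- compound 2 `O=C(CSc1nnc(-c2ccncc2)o1)N/N=C/c1ccc([N+](=O)[O-])cc1` gives 17900 nM
- compound 3 `O=C(CSc1nnc(-c2ccncc2)o1)N/N=C/c1ccccc1[N+](=O)[O-]` gives 24700 nM

Compound 2 has the second highest of the three numbers: its nearest neighbour is compound 3, a 1.4-fold higher number from compound 2 to compound 3 (0.14 log units; within the scatter), and its furthest is compound 1, a 1.5-fold higher number from compound 1 to compound 2 (0.16 log units; within the scatter), so all three values sit within the scatter of one another and no order among them can be claimed.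

The next compound, compound 4 `O=C(CSc1nnc(-c2ccncc2)o1)N/N=C/c1cc(Br)cc(Br)c1O`, differs from compound 2 in one place: 3,5-dibromo-2-hydroxyphenyl in place of 4-nitrophenyl on a carbon with a double bond to nitrogen.

For the measured compounds named here, no measured step exchanges the aryl ring for one carrying hydroxyl and bromine, so nothing bears on the change directly. The steps that do exist on this position, a 2.0-fold higher number from compound 1 to compound 3 (0.30 log units; within the scatter) and a 1.4-fold higher number from compound 2 to compound 3 (0.14 log units; within the scatter), both stayed within the scatter, and the substituent swap a 1.5-fold higher number from compound 1 to compound 2 (0.16 log units; within the scatter) did likewise. On that basis the step of a 1.2-fold lower number from compound 2 to compound 4 (0.08 log units; within the scatter) is expected to stay within the scatter as well, with no direction favoured.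

Compound 4 is therefore estimated at 15000 nM, with a range from 6000 nM to 40000 nM.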

Compound 4, half-maximal inhibitory concentration: 6540 nM
Estimate against measurement, compound 4: 2.3-fold (0.36 log units) above; the range from low to high includes it.
By their numbers in this assay, from the lowest: compounds 4, 1, 2 and 3 (each within the scatter of the next, the first and the last beyond it).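

On the aryl ring on a carbon with a double bond to nitrogen, the earlier swaps gave no step beyond the scatter; in this assay this position now shows two, a 2.7-fold lower number from compound 2 to compound 4 (0.44 log units; beyond the scatter) and a 3.8-fold lower number from compound 3 to compound 4 (0.58 log units; beyond the scatter) with 3,5-dibromo-2-hydroxyphenyl entering in place of a nitrophenyl ring. The same group in place of 4-fluorophenyl gives only a 1.9-fold lower number from compound 1 to compound 4 (0.27 log units; within the scatter) and that step stays within the scatter, so compound 4 separates from the two nitro compounds but not from compound 1. No available data give a reason for these differences.

The entering ring brings hydroxyl and bromine together, so the compounds shown do not assign the steps to either one. As far as these compounds go, how a ring carrying an amine or a carboxylic acid at this position would compare also remains open.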